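A few compounds are considered here, and "the series" means these few. Any claim that something is new, unique, unknown or untested is made for them only; others in the source may bear on it.

Compound 1 `C=CCNC(=O)n1c(-c2ccc(OC)cc2)cc(=O)c2c(OC)cc(OC)cc21` was tested in a functional assay on HepG2 cells (Homo sapiens) for antiproliferative activity, with a stated time of 72 h; a lower number here means that less compound is needed, a higher number that more compound is needed for the effect. In this assay compound 1 reaches only a limit of the assay, > 20000 nM, and not a number. Compound 2 `COc1ccc(-c2c(Br)c(=O)c3c(OC)cc(OC)cc3n2S(=O)(=O)c2ccc(OC)cc2)cc1` was tested in the same way. In this assay compound 2 likewise stops at the limit, > 20000 nM. Compound 1 therefore stands where every measured value sits: the limit of > 20000 nM in this assay, at which 2 of the 2 values shown sit. Compound 3 `COc1ccc(-c2cc(=O)c3c(OC)cc(OC)cc3n2S(=O)(=O)c2ccc(OC)cc2)cc1` has not yet been measured. It differs from compound 1 in one place: (4-methoxyphenyl)sulfonyl in place of allylcarbamoyl on an aromatic nitrogen. For the measured compounds named here, no step between two measured compounds is available to show how such a change plays out here. Since both measured values show no effect up to the limit, a move in this assay beyond the scatter in either direction cannot be read from them, and another limit is the most likely outcome. Compound 3 is therefore expected to give about 30000 nM in this assay, within 10000 nM to 100000 nM. The step this estimate means, a step that the limit leaves unreadable from compound 1 to compound 3, is expected to stay within the scatter.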

Compound 3, half-maximal effective concentration: > 82700 nM
Compound 3 was reported as a limit; the forecaster's own chance of this, stated with the estimate: 75%; middle value at least 2.7-fold (0.44 log units) away from the limit.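

For the compounds shown here, compound 1, compound 2 and compound 3 all stop at limits in this assay, so neither the step from compound 1 to compound 3 nor the one from compound 2 to compound 3 can be read. The compounds shown leave open which change to the shared core, if any, would produce a measurable antiproliferative effect.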